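The source may hold more compounds than are shown below. What is called first, only, known or untested is meant among the compounds shown, and "the series" means these compounds.

For the measured compounds named here, in a functional assay on B16-F0 cells (Mus musculus) for inhibition, read by CCK-8 assay, with a stated time of 48 h (a lower number here means a stronger inhibitor, a higher number a weaker inhibitor), three compounds sharing one core have numbers so far. Compound 1 `COc1cc(-c2ccnc3cc(-c4ccc(F)cc4)nn23)cc(OC)c1OC`, carrying 4-fluorophenyl, gives 4540 nM. Compound 2 `COc1cc(-c2ccnc3cc(-c4c[nH]c5ccccc45)nn23)cc(OC)c1OC`, carrying 1H-indol-3-yl, gives 40 nM, and compound 3 `COc1cc(-c2ccnc3cc(-c4ccc5cc[nH]c5c4)nn23)cc(OC)c1OC`, carrying 1H-indol-6-yl, gives 55 nM. Compound 3 therefore stands level with compound 2, with a 1.4-fold higher number from compound 2 to compound 3 (0.14 log units; within the scatter), and far from compound 1, with an 83-fold lower number from compound 1 to compound 3 (1.92 log units; beyond the scatter).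

Compound 4 `C=Cc1ccc(-c2cc3nccc(-c4cc(OC)c(OC)c(OC)c4)n3n2)cc1` departs from compound 3 at a single site: 4-vinylphenyl in place of 1H-indol-6-yl on an aromatic carbon. There, 4-vinylphenyl takes the place of 1H-indol-6-yl on an aromatic carbon. Going by the values given here, the steps that bear on this are the two large ones out of compound 1, the one already given and a 110-fold lower number from compound 1 to compound 2 (2.05 log units; beyond the scatter). Compound 4 has a single benzene-type ring of carbon only at this site, as compound 1 does, so much of that gain is expected to be lost. Among the compounds with values here, no measured compound carries a vinyl group, which leaves the size open. A large step towards a higher number is therefore expected in this assay, and the estimated step is a 13-fold higher number from compound 3 to compound 4 (1.10 log units; beyond the scatter). Compound 4 is estimated at 700 nM, within an expected range of 100 nM to 5000 nM.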

Compound 4, half-maximal inhibitory concentration: 788 nM
Compound 4: middle estimate off by 1.1-fold (0.05 log units), on the low side, and the stated range covers the measured number.
By their numbers in this assay, from the lowest: compounds 2 and 3 (each within the scatter of the next); then compound 4; then compound 1.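

In this assay, the position on the five-membered aromatic ring responds to the group carried on a carbon-only ring, not only to the choice between that ring and an indole: with the ring kept, vinyl in place of fluoro gives a 5.8-fold lower number from compound 1 to compound 4 (0.76 log units; beyond the scatter). That change does not recover what the indoles give, as 4-vinylphenyl in place of 1H-indol-6-yl gives a 14-fold higher number from compound 3 to compound 4 (1.16 log units; beyond the scatter), and in place of 1H-indol-3-yl it gives a 20-fold higher number from compound 2 to compound 4 (1.29 log units; beyond the scatter). Nothing measured on these compounds accounts for any of these steps.

The compounds shown leave open how an ethyl or a methoxy group on the same ring would compare with vinyl. They also leave open whether the indole's nitrogen hydrogen counts, a question that a 1-methyl-1H-indol-3-yl group at this position would address.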